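Acylhydrazones of diiodophenol aldehydes: cytotoxicity notes

The source may report more compounds than this note shows. Statements on the series, on what has been measured and on what is new or still open speak of the compounds shown alone.

Measured compounds:
- compound 1 `O=C(N/N=C/c1cc(I)cc(I)c1O)c1ccc(C(F)(F)F)cc1`: 11700 nM
- compound 2 `O=C(N/N=C/c1cc(I)cc(I)c1O)c1ccc([N+](=O)[O-])cc1`: 24700 nM
- compound 3 `O=C(N/N=C/c1cc(I)c(O)c(I)c1)c1ccc(C(F)(F)F)cc1`: 57400 nM

In a functional assay on HepG2 cells (Homo sapiens) for cytotoxicity, with a stated time of 24 h (on this read-out lower numbers stand for stronger inhibition and higher numbers for weaker inhibition), compound 1 gives 11700 nM and compound 2 gives 24700 nM. The change between them is nitro in place of trifluoromethyl on an aromatic carbon and produced a 2.1-fold higher number from compound 1 to compound 2 (0.32 log units; beyond the scatter). Compound 3 carries the same atoms as compound 1 joined differently; the difference between the two cores is not broken down here. In this assay compound 3 gives 57400 nM, the highest number of the three, with compound 1 a clear step lower.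

Compound 4 `O=C(N/N=C/c1cc(I)c(O)c(I)c1)c1ccc([N+](=O)[O-])cc1` has not yet been measured in this assay. It differs from compound 3 by nitro in place of trifluoromethyl on an aromatic carbon, the same change as from compound 1 to compound 2, in the same place on the ring. Given a 2.1-fold higher number from compound 1 to compound 2 (0.32 log units; beyond the scatter) and the value of compound 3 57400 nM, the expected step is a 2.0-fold higher number from compound 3 to compound 4 (0.30 log units; within the scatter), a modest rise in the number. For compound 4 the estimate in this assay is 115000 nM, between 50000 nM and 260000 nM, with some chance that the assay reports only a limit.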

Compound 4, half-maximal inhibitory concentration: 92100 nM
Estimate against measurement, compound 4: 1.2-fold (0.10 log units) above, within the range that was stated.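

In this assay, nitro in place of trifluoromethyl on the core of compound 3 gives a 1.6-fold higher number from compound 3 to compound 4 (0.21 log units; within the scatter). Going by these compounds alone, this step reads as no different from the step for the same change on the core of compound 1, so within these two pairs the change carries from one core to the other without a measurable difference: the same change on two cores in this assay, a 2.1-fold higher number (0.32 log units; beyond the scatter) from compound 1 to compound 2 and a 1.6-fold higher number (0.21 log units; within the scatter) from compound 3 to compound 4, 1.3-fold (0.12 log units) apart, within the scatter of two such steps This rests on only two pairs and one exchange of groups, and the step on the core of compound 3 lies within the scatter on its own, so it shows neither a general rule for other cores nor why the numbers take these values.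

Still open, on these data alone, is how an amine, a carboxylic acid or a methoxy group on the same aromatic carbon would read in this assay, on either core. Also open, as far as these compounds go, is whether the agreement between the two steps would hold with bromine or chlorine in place of the iodines, or with the hydroxyl replaced by a methoxy group.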